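The source may hold more compounds than are shown below. What is called first, only, known or untested is meant among the compounds shown, and "the series" means these compounds.

In a functional assay on NCI-H460 cells (Homo sapiens) for inhibition, read by MTT assay, with a stated time of 24 h, tested at 0.1 ug/mL (on this read-out lower numbers stand for less inhibition of growth and higher numbers for more inhibition of growth at the one concentration tested), compound 1 (`O=C(CCCCC1CCSS1)NO`) gives 3.9% and compound 2 (`O=C(CCCCC1CCSS1)Nc1ccccn1`) gives 2.61%. These two numbers lie within the scatter of each other, so compound 2 cannot be ranked against compound 1, and no other measured value is available to place it. Compound 3 (`O=C(CCCCC(S)CCS)Nc1ccccn1`) keeps the pyridin-2-yl amide of compound 2 and differs at the far end of the chain: a group of 5 heavy atoms (3 carbon, 2 sulfur; no ring) in place of a group of 5 heavy atoms (3 carbon, 2 sulfur; one five-membered non-aromatic ring with 2 hetero atoms), on a saturated chain carbon, four bonds along the chain from a carbonyl carbon. Put simply, the ring is gone and 1,3-disulfanylpropyl stands in its place. For the measured compounds named here, only one measured step exists, a number 1.3 percentage points lower from compound 1 to compound 2 (within the scatter), and it concerns the group on the amide-type nitrogen, so no measurement yet touches the ring itself. That step offers no direction for the new change, and no shift beyond the scatter is expected, although the lack of any direct precedent argues for a wide range. The expected step is a number 2.4 percentage points higher from compound 2 to compound 3 (within the scatter). In this assay, the estimated value for compound 3 is 5%, with an expected range from 0% to 16%.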

Compound 3, percent growth inhibition at one concentration: 5.01%
Compound 3: the middle estimate sits 0 percentage points below what was measured; the measured number falls inside the stated range.
By their numbers in this assay, from the lowest: compounds 2, 1 and 3 (each within the scatter of the next).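

In this assay the far end of the chain comes into play for the first time among these compounds, and replacing the ring with 1,3-disulfanylpropyl gives a number 2.4 percentage points higher from compound 2 to compound 3 (within the scatter) on a saturated chain carbon, four bonds along the chain from a carbonyl carbon. The closed ring and the open form therefore cannot be told apart in this measurement, even though the change removes the ring and brings in hydrogen-bond donors. Nothing available explains this result or shows what either form does in the cells.

Going by these compounds, whether a carboxylic acid or an amine at this place, or a longer chain ahead of the 1,3-disulfanylpropyl group, would move the number beyond the scatter remains open. Also open, on these data alone, is whether 1,3-disulfanylpropyl paired with the hydroxy group on the amide-type nitrogen would match its pairing with pyridin-2-yl, and whether these compounds would separate at any concentration other than the one tested.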